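The compounds below may be only part of what the source reports. "The series", "measured", "known", "first", "only" and "open" are said of these compounds alone.

Compound 1 `Cc1ccc(-n2nc(-c3ccc(C(F)(F)F)cc3O)nc2-c2ccccc2O)cc1`: 94.1%
Compound 2 `CCc1ccc(-n2nc(-c3ccc(C(F)(F)F)cc3O)nc2-c2ccccc2O)cc1`: 95.4%
Compound 3 `CC(C)(C)c1ccc(-n2nc(-c3ccc(C(F)(F)F)cc3O)nc2-c2ccccc2O)cc1`: 77.8%

In a functional assay on PC-12 cells (Rattus norvegicus) for cytotoxicity, read by MTT assay, with stated times of 2 h and 24 h, tested at 5 uM (a lower number here means a weaker effect, a higher number a stronger effect of the compound at the concentration tested), compound 3 stands lowest of the three measured compounds. The steps of a number 16.3 percentage points lower from compound 1 to compound 3 (beyond the scatter) and a number 17.6 percentage points lower from compound 2 to compound 3 (beyond the scatter) both lie beyond the scatter, while a number 1.3 percentage points higher from compound 1 to compound 2 (within the scatter) lies within it, so compound 1 and compound 2 cannot be told apart. Compound 4 `Oc1cc(C(F)(F)F)ccc1-c1nc(-c2ccccc2O)n(-c2ccc(Cl)cc2)n1` differs from compound 3 in one place: chloro in place of tert-butyl on an aromatic carbon. The two steps leading to compound 3 bear on this, since in both the arrival of tert-butyl went with a modestly lower number; here tert-butyl leaves. Among the measured compounds shown here, no measured compound carries chloro, so the expectation rests on that departure alone. A modest rise is therefore expected, a number 10.2 percentage points higher from compound 3 to compound 4 (beyond the scatter). Compound 4 is estimated at 88%, between 74% and 100%.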

Compound 4, a percentage reported as activity, at one concentration (the size of the read-out at that concentration, not a potency): 87.3%
Estimate against measurement, compound 4: 0.7 percentage points above; measured number inside the range.
By their numbers in this assay, from the lowest: compounds 3, 4, 1 and 2 (each within the scatter of the next, the first and the last beyond it).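

With chloro at this position, this assay gives a number that cannot be told apart from any of the other three: the steps read (a number 9.5 percentage points higher from compound 3 to compound 4 (within the scatter)), (a number 8.1 percentage points lower from compound 2 to compound 4 (within the scatter)) and (a number 6.8 percentage points lower from compound 1 to compound 4 (within the scatter)). Chloro therefore joins neither side of the gap that separates tert-butyl from methyl and ethyl, and this one compound cannot place it on either side. Nothing measured here explains these numbers. On these data alone, it remains open how an amine, a methoxy group or a carboxylic acid would read at this position. Also open, as far as these compounds go, is whether a longer chain would read like ethyl or like tert-butyl.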